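Replacing an aromatic ring with a saturated bicycle

A few compounds are considered here, and "the series" means these few. Any claim that something is new, unique, unknown or untested is made for them only; others in the source may bear on it.

Two compounds share one core and differ only in the group on the carbonyl carbon. Compound 1 `C[C@@H](NC(=O)Nc1ccc(Cl)cc1)[C@H]1CC[C@@H](c2ccnc3ccc(F)cc32)CC1` carries a (4-chlorophenyl)amino there and in an assay on tissue (HeLa cells) for inhibition of Indoleamine 2,3-dioxygenase 1 (Homo sapiens), with stated times of 2 h and 18 h (a higher number here means a weaker inhibitor, a lower number a stronger inhibitor), compound 1 gives 20 nM. Compound 2 `C[C@@H](NC(=O)c1ccccc1Cl)[C@H]1CC[C@@H](c2ccnc3ccc(F)cc32)CC1` carries a 2-chlorophenyl instead, and in this assay compound 2 gives 12 nM. The change a 1.7-fold lower number from compound 1 to compound 2 (0.22 log units; within the scatter) is small, so compound 2 has the lowest of the two numbers without being separated from compound 1 beyond the scatter.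

Compound 3 `C[C@@H](NC(=O)C12CCC(Cl)(CC1)CC2)[C@H]1CC[C@@H](c2ccnc3ccc(F)cc32)CC1` is not yet measured. It differs from compound 2 by a group of 9 heavy atoms (8 carbon, 1 chlorine; 2 six-membered non-aromatic rings of carbon only) in place of a group of 7 heavy atoms (6 carbon, 1 chlorine; one six-membered aromatic ring of carbon only), on a carbonyl carbon, so an aromatic ring gives way to two non-aromatic rings that still carry one chlorine. Among the measured compounds shown here, no measured step covers this kind of change; the only step available, from urea to amide, stayed within the scatter and does not predict the effect of a saturated bicycle. The expectation for compound 3 therefore rests on compound 2 alone, with a wide range in either direction and no shift beyond the scatter assumed. Compound 3 is expected to give 20 nM in this assay, between 6 nM and 70 nM, which is an expected step of a 1.7-fold higher number from compound 2 to compound 3 (0.22 log units; within the scatter).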

Compound 3, half-maximal inhibitory concentration: 24 nM
The estimate for compound 3 lay 1.2-fold (0.08 log units) below the measured number; the measured number falls inside the stated range.
By their numbers in this assay, from the lowest: compounds 2, 1 and 3 (each within the scatter of the next).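

Two non-aromatic rings of carbon only, still carrying one chlorine, can stand in for the aromatic ring of the 2-chlorophenyl on this carbonyl carbon: in this assay the change amounts to a 2.0-fold higher number from compound 2 to compound 3 (0.30 log units; within the scatter) and so does not separate the two compounds. Set against the urea of compound 1, the new group gives a 1.2-fold higher number from compound 1 to compound 3 (0.08 log units; within the scatter) and again stays inside the usual variation, so among these three compounds a flat aromatic ring on this carbonyl carbon is not needed for a number in this range. Nothing measured here explains why the saturated group is tolerated, and no supporting data bear on the result.

The compounds shown leave open whether the chlorine itself contributes, since both the aromatic and the saturated groups carry one, and a bicycle bearing plain hydrogen, a fluorine or a nitrile in its place would test that. They also leave open how far this tolerance extends, for instance to a bicycle carrying an amine or a carboxylic acid, or to a single cyclohexyl ring on the same carbonyl carbon.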